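Dimethylamino in place of phenoxy in a cytotoxicity series

The source may hold more compounds than are shown below. What is called first, only, known or untested is meant among the compounds shown, and "the series" means these compounds.

Measured compounds:
compound 1, `COc1cc(C)cc(-c2nn(CC#N)cc2-c2ccc(-c3cccc(C(C)=O)c3)nc2)c1`, 21%
compound 2, `Cc1cc(O)cc(-c2nn(CC#N)cc2-c2ccnc(-c3ccc(Oc4ccccc4)cc3)c2)c1`, 19%

In a functional assay on UO-31 cells (Homo sapiens) for cytotoxicity, read by sulforhodamine B assay, with a stated time of 48 h, tested at 1 uM (a lower number here means a stronger effect, a higher number a weaker effect of the compound at the concentration tested), compound 2 gives 19%. Compound 1 gives 21% in this assay, and the two numbers lie within the scatter of each other, so neither can be called stronger. Compound 3, `Cc1cc(O)cc(-c2nn(CC#N)cc2-c2ccnc(-c3ccc(N(C)C)cc3)c2)c1`, is not yet measured in this assay. It differs from compound 2 in one place: dimethylamino in place of phenoxy on an aromatic carbon. Among the measured compounds shown here, no measured pair shows such a step, so the expectation rests on compound 2 alone. The estimate for compound 3 in this assay is 25%, within 5% to 60%. The expected step of a number 6 percentage points higher from compound 2 to compound 3 (within the scatter) is small, not clearly beyond the scatter.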

Compound 3, a percentage reported as activity, at one concentration (the size of the read-out at that concentration, not a potency): 19%
The estimate for compound 3 lay 6 percentage points above the measured number, and the stated range covers the measured number.
By their numbers in this assay, from the lowest: compounds 2, 3 and 1 (each within the scatter of the next).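

In this assay, dimethylamino in place of phenoxy gives no change at the digits printed from compound 2 to compound 3 (within the scatter), so the two compounds cannot be told apart at the one concentration tested. This aromatic carbon thus carries either group, one with a six-membered aromatic ring and one with no ring and fewer heavy atoms, with readings within the scatter. Nothing at hand explains this result.

On these data alone, whether a primary amine, a morpholine or a carboxylic acid on this carbon would read the same remains open. A single concentration also leaves the potency of compound 2 and compound 3 undefined.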